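A Piperazine Takes the Place of Ureido

The source may report more compounds than this note shows. Statements on the series, on what has been measured and on what is new or still open speak of the compounds shown alone.

Measured in a functional assay on HL-60 cells (Homo sapiens) for cytotoxicity, read by MTT assay, with a stated time of 3 days; a higher number here means a weaker inhibitor, a lower number a stronger inhibitor:
Compound 1 `N#Cc1c(Nc2ccccc2)nc(SCc2nc3ccccc3[nH]2)nc1-c1ccccc1`: 4.46 nM
Compound 2 `N#Cc1c(NC(N)=O)nc(SCc2nc3ccccc3[nH]2)nc1-c1ccccc1`: 2.9 nM

On these numbers, compound 2 stands level with compound 1 within the scatter. Compound 3 `N#Cc1c(-c2ccccc2)nc(SCc2nc3ccccc3[nH]2)nc1N1CCNCC1` follows from compound 2 by one change: piperazin-1-yl in place of ureido on an aromatic carbon. The group sits ortho to a cyano group. For the measured compounds named here, the only measured step bearing on this place is a 1.5-fold lower number from compound 1 to compound 2 (0.19 log units; within the scatter). One small step says little about a ring entering here, so no step beyond the scatter is expected in this assay, and the range is kept wide. The expected change is a 1.7-fold higher number from compound 2 to compound 3 (0.24 log units; within the scatter). The estimate for compound 3 is 5 nM, with an expected range from 1.2 nM to 20 nM.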

Compound 3, half-maximal inhibitory concentration: 4 nM
Compound 3: the middle estimate sits 1.3-fold (0.10 log units) above what was measured, within the range that was stated.
By their numbers in this assay, from the lowest: compounds 2, 3 and 1 (each within the scatter of the next).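

In this assay, the aromatic carbon ortho to a cyano group takes a six-membered non-aromatic ring and the numbers stay level: a 1.4-fold higher number from compound 2 to compound 3 (0.14 log units; within the scatter) and a 1.1-fold lower number from compound 1 to compound 3 (0.05 log units; within the scatter). Anilino, ureido and piperazin-1-yl thus read alike at this place, so none of the three stands apart here. Nothing available explains this sameness. The compounds shown leave open whether morpholin-4-yl, 4-methylpiperazin-1-yl or an open-chain amine such as dimethylamino would read alike on this carbon.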